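This account rests on a few compounds, and the source may have more. Where it says the series, first, only, none or still open, it means among the compounds named here.

Of the compounds shown here, three sharing one core have been measured in an assay on CHO cells for displacement of a labelled ligand from adenosine receptor A3 (Homo sapiens), read by scintillation counting, with a stated time of 45 min, tested at 1 uM, in the presence of a further agent that is not named here; on this read-out higher numbers stand for more inhibition at the one concentration tested (going by the name of the read-out) and lower numbers for less inhibition. Compound 1 `CCCn1c(=O)[nH]c2nc(-c3ccc(S(=O)(=O)N4CCN(c5ccc(Br)cc5)CC4)cc3)[nH]c2c1=O` gives 29% in this assay. Compound 2 `CCCn1c(=O)[nH]c2nc(-c3ccc(S(=O)(=O)N4CCN(C)CC4)cc3)[nH]c2c1=O` gives 7%, and compound 3 `CCCn1c(=O)[nH]c2nc(-c3ccc(S(=O)(=O)N4CCN(Cc5cccc(Br)c5)CC4)cc3)[nH]c2c1=O` gives 23%. Compound 3 stands second highest of the three numbers: the step of a number 6 percentage points lower from compound 1 to compound 3 (within the scatter) is within the scatter, while the step of a number 16 percentage points higher from compound 2 to compound 3 (beyond the scatter) is beyond it.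

Compound 4 `CCCn1c(=O)[nH]c2nc(-c3ccc(S(=O)(=O)N4CCN(c5ccccc5Br)CC4)cc3)[nH]c2c1=O` has not yet been measured. It differs from compound 3 in one place: 2-bromophenyl in place of 3-bromobenzyl on an amine nitrogen in a ring. Within the data shown here, two measured steps bear on this change. The step of a number 6 percentage points lower from compound 1 to compound 3 (within the scatter) shows that exchanging 4-bromophenyl for 3-bromobenzyl on the amine nitrogen in the ring made no difference beyond the scatter, and the step of a number 22 percentage points lower from compound 1 to compound 2 (beyond the scatter) shows that replacing that aromatic ring by a methyl lowered the number modestly. Compound 4 keeps a six-membered aromatic ring with a bromine on that nitrogen, as compound 1 and compound 3 do. Among the measured compounds shown here, no measured step compares 2-bromophenyl with another bromophenyl group, so nothing here separates the two. The step from compound 3 is therefore expected to be small, a number 3 percentage points higher from compound 3 to compound 4 (within the scatter), within the scatter. Compound 4 is estimated to give 26% in this assay, between 12% and 40%.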

Compound 4, a percentage reported as inhibition, at one concentration (the size of the read-out at that concentration, not a potency): 20%
Estimate against measurement, compound 4: 6 percentage points above, within the range that was stated.
By their numbers in this assay, from the lowest: compound 2; then compounds 4, 3 and 1 (each within the scatter of the next).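

In this assay, among these compounds, the first direct comparison of two bromophenyl groups on the amine nitrogen in the ring, a number 9 percentage points lower from compound 1 to compound 4 (within the scatter), shows no difference beyond the scatter, and neither does the exchange of a 3-bromobenzyl group for a 2-bromophenyl group, a number 3 percentage points lower from compound 3 to compound 4 (within the scatter). The comparison with the small group, a number 13 percentage points higher from compound 2 to compound 4 (beyond the scatter), adds a further case to the earlier two: compounds 1, 3 and 4, each with a bromine-bearing aromatic ring at this position, all stand apart from the methyl compound, and none of the shown compounds goes against this. Nothing measured here offers an explanation for why these three bromine-bearing groups cannot be told apart in this read-out.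

The shown compounds leave open how a plain phenyl group or a 2-chlorophenyl group would read on this nitrogen, and so whether the bromine or the aromatic ring itself goes with the higher numbers. With only one concentration tested, they also leave open how compounds 1, 3 and 4 would compare across a range of concentrations.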